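A Triazole Substituent Swap Against a Gastric Cancer Cell Line

The source may report more compounds than this note shows. Statements on the series, on what has been measured and on what is new or still open speak of the compounds shown alone.

Measured in a functional assay on MGC-803 cells (Homo sapiens) for inhibition, read by MTT assay, with a stated time of 72 h; a lower number here means a stronger inhibitor, a higher number a weaker inhibitor:
compound 1 `CC(C)n1ncc2c(C(=O)NCc3ccccc3)cccc21` gives > 40000 nM;
compound 2 `Cc1cccc(-n2cc(CNC(=O)c3cccc4c3cnn4C(C)C)nn2)c1` gives > 40000 nM.

Compound 2 sits at the detection limit of this assay, so its value is a limit and not a number. The same holds for compound 1, whose value is also a limit. Both of the values shown are limits, as the limit of > 40000 nM in this assay, at which 2 of the 2 values shown sit, records, so nothing about the size of a step between measured compounds can be read from them.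

Compound 3 `COc1ccc(Cn2cc(CNC(=O)c3cccc4c3cnn4C(C)C)nn2)cc1` differs from compound 2 in one place: 4-methoxybenzyl in place of 3-methylphenyl on an aromatic nitrogen. Among the measured compounds shown here, since no measured step exists here, the direction of this change is not known from the data; the expectation is for no step beyond the usual scatter in this assay. Compound 3 is therefore estimated at 45000 nM, within 10000 nM to 200000 nM, which means an expected step that the limit leaves unreadable from compound 2 to compound 3.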

Compound 3, half-maximal inhibitory concentration: > 40000 nM
Compound 3: a limit, no number (the forecaster's own chance of this, stated with the estimate: 75%); the middle value lies beyond the limit too.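

In this assay compound 3 gives > 40000 nM, which is a limit and not a number. Compound 2 also stands at a limit, so no step between compound 2 and compound 3 can be read: the limit of > 40000 nM in this assay, at which 3 of the 3 values shown sit.

The compounds shown leave open whether 4-methoxybenzyl and 3-methylphenyl on the aromatic nitrogen differ at all in their inhibition of these cells.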